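The compounds below may be only part of what the source reports. "The series", "measured", "known", "first", "only" and "open" are said of these compounds alone.

Compound 1 `CCCC/C(=C\c1cc(Oc2ccccc2)ccc1OCc1ccc(C(F)(F)F)cc1)C(=O)O` gives 2100 nM in an assay on isolated protein for inhibition of Polyunsaturated fatty acid 5-lipoxygenase (Homo sapiens), read by HPLC, with a stated time of 15 min; on this read-out higher numbers stand for weaker inhibition and lower numbers for stronger inhibition. Compound 2 `CCCC/C(=C\c1cc(OCc2cccnc2)ccc1OCc1ccc(C(F)(F)F)cc1)C(=O)O` gives 2300 nM in this assay.

Compound 2 holds the highest of these two numbers, with compound 1 nearest; the step of a 1.1-fold higher number from compound 1 to compound 2 (0.04 log units; within the scatter) lies within the scatter. Compound 3 `CCCC/C(=C\c1cc(OCc2ccc(-c3csc(C)n3)cc2)ccc1OCc1ccc(C(F)(F)F)cc1)C(=O)O` differs from compound 2 by 4-(2-methyl-1,3-thiazol-4-yl)phenyl in place of pyridin-3-yl on a saturated chain carbon bound to an oxygen on an aromatic ring. Within the data shown here, the only step bearing on this change is the one from compound 1 to compound 2, which swapped the group on the same oxygen and was within the scatter. Compound 3 is therefore expected to show no step beyond the scatter, no change at the digits printed from compound 2 to compound 3 (within the scatter). The estimate for compound 3 is 2300 nM, with a range from 1000 nM to 5500 nM.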

Compound 3, half-maximal inhibitory concentration: 6700 nM
For compound 3 the middle estimate is 2.9-fold (0.46 log units) below the measured one; measured number above the stated range.
By their numbers in this assay, from the lowest: compounds 1 and 2 (each within the scatter of the next); then compound 3.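

In this assay, 4-(2-methyl-1,3-thiazol-4-yl)phenyl in place of pyridin-3-yl on a saturated chain carbon bound to an oxygen on an aromatic ring gives a 2.9-fold higher number from compound 2 to compound 3 (0.46 log units; beyond the scatter) and so modestly weaker inhibition. Among these compounds, this is the first step beyond the scatter at this part of the molecule, so the group placed here can change the read-out. Nothing measured here accounts for the step.

On these data alone, whether the thiazole or the added phenyl ring carries the step stays open. So does the reading for an amine or a carboxylic acid at this place.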